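The source may hold more compounds than are shown below. What is called first, only, known or untested is meant among the compounds shown, and "the series" means these compounds.

Measured in an ADME assay on HepG2 2.2.15 cells (Homo sapiens) for cytotoxicity, read by MTT assay, with a stated time of 72 h; on this read-out higher numbers stand for lower toxicity in this test and lower numbers for higher toxicity in this test:

- Compound 1 `CC(=O)OCc1cccc2c1CCOC2=O`: > 2430000 nM (a limit)
- Compound 2 `O=C(OCc1cccc2c1CCOC2=O)c1cccc([N+](=O)[O-])c1`: > 2720000 nM (a limit)
- Compound 3 `O=C(O)c1ccccc1C(=O)OCc1cccc2c1CCOC2=O`: 130000 nM

Compound 1 has the entry > 2430000 nM, which is a limit, not a number. For compound 2, which also carries an aromatic ring on the corresponding carbonyl carbon, the entry > 2720000 nM is likewise a limit. Compound 3 goes against this picture, with a measured 130000 nM.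

Compound 4 `O=C(OCc1cccc2c1CCOC2=O)c1ccco1` keeps the shared core of compound 1, with furan-2-yl in place of methyl on a carbonyl carbon. Within the data shown here, no step between measured compounds is available, so the expectation in this assay rests on the two limits, and no change beyond the scatter is expected. The estimated change is a step that the limit leaves unreadable from compound 1 to compound 4. The range is kept wide on the low side since compound 3 reads 130000 nM. Compound 4 is expected at 2500000 nM, with an estimated range from 400000 nM to 4000000 nM.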

Compound 4, half-maximal cytotoxic concentration: > 2350000 nM
Compound 4: only a limit was reported; the forecaster's own chance of this, stated with the estimate: 65%; the middle value is on the limit's open side.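

In this assay, among these compounds, compound 1 and compound 4 are both reported only as limits, and no step from one to the other can be read. The compounds shown leave open whether furan-2-yl in place of methyl on a carbonyl carbon changes the half-maximal cytotoxic concentration at all.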